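Changing the aryl group of compound 2

This account rests on a few compounds, and the source may have more. Where it says the series, first, only, none or still open, it means among the compounds named here.

In a functional assay on HL-60 cells (Homo sapiens) for inhibition, read by MTT assay, with a stated time of 72 h (a higher number here means a weaker inhibitor, a lower number a stronger inhibitor), compound 1 `Cc1nc(-c2ccc(F)cc2)c(C(=O)N2CCN(c3cccc(Cl)c3)CC2)o1` gives 40.1 nM and compound 2 `CCc1nc(-c2ccc(F)cc2)c(C(=O)N2CCN(c3cccc(Cl)c3)CC2)o1` gives 169 nM, the higher of these two numbers. Compound 3 `O=C(c1oc(C(F)(F)F)nc1-c1ccc(F)cc1)N1CCN(c2cccc(Cl)c2)CC1` is reported without a number, as "not active" (no number reported). Compound 4 `CCc1nc(-c2ccc(OC)c(OC)c2)c(C(=O)N2CCN(c3cccc(Cl)c3)CC2)o1` keeps the ethyl group of compound 2 but carries 3,4-dimethoxyphenyl in place of 4-fluorophenyl on an aromatic carbon. Within the data shown here, no measured step touches this place. Among the measured compounds shown here, the only measured step, a 4.2-fold higher number from compound 1 to compound 2 (0.62 log units; beyond the scatter), lies at the ethyl group, so it hints at a possible size but gives no direction. With so little to go on, no change beyond the scatter is confidently expected, and the estimated step is a 1.2-fold higher number from compound 2 to compound 4 (0.07 log units; within the scatter). In this assay the estimate for compound 4 is 200 nM, with an expected range from 40 nM to 1000 nM.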

Compound 4, half-maximal inhibitory concentration: "not active" (no number reported)
Compound 4: no number reported; no gap can be computed for the estimate.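

Among these compounds, compound 4 is reported as not active, without a number, and no step from compound 2 to compound 4 can be read. The compounds shown leave open how far compound 4 lies from compound 2. Nothing available explains this result.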